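The compounds below may be only part of what the source reports. "The series", "measured", "known", "first", "only" and "open" are said of these compounds alone.

Compound 1, `CC(Cn1ncccc1=O)C(=N)S`, in a functional assay on the whole organism (stomach) with Rattus norvegicus as the target (on this read-out lower numbers stand for an effect already at smaller amounts and higher numbers for an effect only at larger amounts of compound), gives > 100 mg/kg, a limit of the assay rather than a number.
Compound 2, `O=c1cccnn1CCC(=S)N1CCCC1`, in this assay gives > 100 mg/kg, again a limit.
Compound 3, `Cc1ccc(=O)n(CCCCCC(=N)S)n1`, in this assay gives > 100 mg/kg, also a limit.

Compound 1 therefore stands at no measured number in this assay; all three results shown sit at the limit of > 100 mg/kg in this assay, at which 3 of the 3 values shown sit. No pair among these compounds gives a measured step, so nothing tells how large a single structural change shifts this read-out.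

Compound 4, `N=C(S)CCn1ncccc1=O`, differs from compound 1 by hydrogen in place of methyl on a saturated chain carbon bound to a carbon with a double bond to nitrogen and a saturated chain carbon. With every neighbour of compound 4 resting at the same limit, the change from compound 1 to compound 4 is expected to produce no step beyond the scatter, and the step that the limit leaves unreadable from compound 1 to compound 4 is the expected one. For compound 4 the expected value in this assay is 150 mg/kg, with a range from 60 mg/kg to 500 mg/kg, and most likely the assay again reports only a limit.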

Compound 4, dose for half-maximal effect: > 100 mg/kg
Compound 4: only a limit was reported (the forecaster's own chance of this, stated with the estimate: 80%); the middle value is on the limit's open side.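

Compound 1 and compound 4 each give a limit of the assay rather than a number, so the exchange of methyl for hydrogen yields no readable step: the limit of > 100 mg/kg in this assay, at which 4 of the 4 values shown sit.

The compounds shown leave open what dose of any of them gives a half-maximal effect in this assay and how far a single structural change moves that dose.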